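A few compounds are considered here, and "the series" means these few. Any claim that something is new, unique, unknown or untested is made for them only; others in the source may bear on it.

Measured so far in a functional assay on SK-BR-3 cells (Homo sapiens) for antiproliferative activity, read by MTT assay, with a stated time of 72 h; a lower number here means a stronger inhibitor, a higher number a weaker inhibitor:
- compound 1 `C/C=C1/[C@H](O[C@@H]2O[C@H](CO)[C@@H](O)[C@H](O)[C@H]2O)OC=C(C(=O)OC)[C@H]1CC(=O)OCCc1ccc(O)c(O)c1`: 160000 nM
- compound 2 `C/C=C1/[C@H](O[C@@H]2O[C@H](COC(C)=O)[C@@H](OC(C)=O)[C@H](OC(C)=O)[C@H]2OC(C)=O)OC=C(C(=O)O)[C@H]1CC(=O)OC`: > 20000 nM, a limit of the assay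
- compound 3 `C/C=C1/[C@H](O[C@@H]2O[C@H](COC(C)=O)[C@@H](OC(C)=O)[C@H](OC(C)=O)[C@H]2OC(C)=O)OC=C(C(=O)OC)[C@H]1CC(=O)OCCC(C)C`: > 15000 nM, a limit of the assay

For the measured compounds named here, compound 1 gives the only number in this assay; the other two results are limits, one at the limit of > 20000 nM in this assay, at which 1 of the 3 values shown sits, and one at the limit of > 15000 nM in this assay, at which 1 of the 3 values shown sits, so no step between measured compounds can be sized. Compound 4 `C/C=C1/[C@H](O[C@@H]2O[C@H](CO)[C@@H](O)[C@H](O)[C@H]2O)OC=C(C(=O)OC)[C@H]1CC(=O)OCCCC` is not yet measured. It differs from compound 1 by ethyl in place of 3,4-dihydroxyphenyl on a saturated chain carbon, two bonds along the chain from an oxygen next to a carbonyl group. Going by the values given here, with no measured step to go on, no change beyond the usual scatter is expected, and a limit rather than a number is a real possibility. Compound 4 is estimated at 200000 nM, range 50000 nM to 800000 nM, an expected step of a 1.3-fold higher number from compound 1 to compound 4 (0.10 log units; within the scatter).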

Compound 4, half-maximal inhibitory concentration: > 15000 nM
Compound 4: only a limit was reported (the forecaster's own chance of this, stated with the estimate: 60%); the middle value is on the limit's open side.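

In this assay compound 4 gives > 15000 nM which is a limit and not a number, so the step from compound 1 to compound 4 cannot be read. As far as these compounds go, whether ethyl in place of 3,4-dihydroxyphenyl changes the result in this assay at all stays open.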